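This account rests on a few compounds, and the source may have more. Where it says the series, first, only, none or still open, it means among the compounds named here.

Series notes on the sulfonamides of the shared core, all tested in a functional assay on HCT-116 cells (Homo sapiens) for inhibition, read by MTT assay, with a stated time of 72 h; on this read-out higher numbers stand for weaker inhibition and lower numbers for stronger inhibition. Compound 1 `CCOC(=O)c1oc2ccc(N(Cc3ccccc3)S(=O)(=O)c3ccc(C)cc3)cc2c1C` is the methyl member. In this assay compound 1 gives > 40000 nM, which is a limit of the assay and not a number. Compound 2 `CCOC(=O)c1oc2ccc(N(Cc3ccccc3)S(=O)(=O)c3ccc(OC)cc3)cc2c1C` has methoxy in place of methyl on an aromatic carbon. In this assay compound 2 gives > 40000 nM, again only a limit. Compound 3 `CCOC(=O)c1oc2ccc(N(Cc3ccccc3)S(=O)(=O)c3ccc([N+](=O)[O-])cc3)cc2c1C` has nitro in place of methyl on an aromatic carbon. In this assay compound 3 gives > 40000 nM, also a limit. The steps a step that the two limits leave unreadable from compound 1 to compound 2, a step that the two limits leave unreadable from compound 1 to compound 3 and a step that the two limits leave unreadable from compound 2 to compound 3 are consequently unreadable, since all three values sit at the limit of > 40000 nM in this assay, at which 3 of the 3 values shown sit. Compound 3 therefore stands where every measured compound stands, at the limit, with no number to rank it.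

Compound 4 `CCOC(=O)c1oc2ccc(N(Cc3ccccc3)S(=O)(=O)c3cccc(Cl)c3)cc2c1C` differs from compound 3 by 3-chlorophenyl in place of 4-nitrophenyl on a sulfonyl sulfur. Within the data shown here, no measured step touches this change, and no measured step has a readable size; the only information is that three sulfonyl aryl variants all failed to reach a number. The expected outcome is the step that the limit leaves unreadable from compound 3 to compound 4, that is, another limit rather than a measurable shift in either direction. Compound 4 is accordingly estimated at 60000 nM, with a range from 20000 nM to 200000 nM.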

Compound 4, half-maximal inhibitory concentration: > 40000 nM
Compound 4: only a limit was reported; the forecaster's own chance of this, stated with the estimate: 80%; the middle value is on the limit's open side.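

Compound 4, like compound 1, compound 2 and compound 3, gives only a limit of the assay and not a number, so no step among these compounds can be read: the limit of > 40000 nM in this assay, at which 4 of the 4 values shown sit.

The compounds shown leave open whether any sulfonyl aryl variant on the shared core reaches a number in this assay.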